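The source may report more compounds than this note shows. Statements on the series, on what has been measured and on what is new or still open speak of the compounds shown alone.

In an ADME assay on MT2 cells (Homo sapiens) for cytotoxicity, read by XTT assay, with a stated time of 4 days (on this read-out higher numbers stand for lower toxicity in this test and lower numbers for higher toxicity in this test), compound 3 (`Cc1nc(C(NC(=O)C(=O)Nc2ccc(F)cc2)C2CCCCN2)sc1CCO`) gives 109000 nM and so stands level with compound 1 (`Cc1ccc(NC(=O)C(=O)NC(c2nc(C)c(CCO)s2)C2CCCCN2)cc1F`), which gives 85000 nM on the same scale. Compound 2 (`Cc1nc(C(NC(=O)C(=O)Nc2ccc(F)cc2F)C2CCCCN2)sc1CO`) carries a different chain on the core along with a 2,4-difluorophenyl group, and its reading, > 110000 nM, is only a limit. Readings in this assay can stop at the limit of > 110000 nM in this assay, at which 1 of the 3 values shown sits, so a plain number is not guaranteed for the next compound either.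

Compound 4 (`Cc1nc(C(NC(=O)C(=O)Nc2ccc(F)cc2F)C2CCCCN2)sc1CCO`) turns the 4-fluorophenyl of compound 3 into 2,4-difluorophenyl, with fluoro in place of hydrogen on an aromatic carbon. For the measured compounds named here, the one measured step on this aromatic group is a 1.3-fold higher number from compound 1 to compound 3 (0.11 log units; within the scatter) so no step beyond the scatter is expected in this assay for this change. The estimated result is a 1.0-fold lower number from compound 3 to compound 4 (0.02 log units; within the scatter) and neither direction is favoured. For compound 4 the estimated value is 105000 nM within an expected range of 70000 nM to 160000 nM and a report as a limit alone is also quite possible.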

Compound 4, half-maximal cytotoxic concentration: > 105000 nM
Compound 4: only a limit was reported; the forecaster's own chance of this, stated with the estimate: 45%; the middle value lies on the limit itself.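

In this assay compound 4 gives > 105000 nM as a limit, not a plain number. The steps to compound 4 from compound 3 and from compound 2 cannot be read, so fluoro in place of hydrogen on this aromatic carbon, ortho to a large group, has no measured size here. The one step that can be read is an at least 1.2-fold higher number from compound 1 to compound 4 (0.09 log units; that floor lies within the scatter) and it gives no sign of a real difference, while among these four compounds the two carrying 2,4-difluorophenyl, compound 2 and compound 4, are the two reported only as limits.

From the compounds shown here alone, how compound 4 truly compares with compound 3 stays open. In this assay, going by these compounds, the reading of a chloro group, a methoxy group or an amine on that same aromatic carbon also stays open.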